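The source may report more compounds than this note shows. Statements on the series, on what has been measured and on what is new or still open speak of the compounds shown alone.

Measured so far in an ADME assay (liver) for metabolic stability, with Liver microsome (Rattus norvegicus) as the target, read by LC-MS, using microsomes and NADPH, with stated times of 5 min and 60 min, tested at 4 uM; a higher number here means that more of the compound is left, a lower number that less of the compound is left:

Compound 1 (`COc1cc(C(=O)O)ccc1OCCCCOc1ccc(C(=O)CC(C)C)c(O)c1C`) 43%
Compound 2 (`Cc1c(OCCCCOc2ccc(C(=O)O)cc2)ccc(C(=O)CC(C)C)c1O`) 66%

Of these two, compound 2 stands highest at 66% in this assay and compound 1 lies clearly under it. Compound 3 (`Cc1cc(OCCCCOc2ccc(C(=O)CC(C)C)c(O)c2C)ccc1C(=O)O`) has not yet been measured. Its difference from compound 2 is this: methyl in place of hydrogen on an aromatic carbon. In words, methyl takes the place of hydrogen on an aromatic carbon, ortho to a carboxy group, turning 4-carboxyphenyl into 4-carboxy-3-methylphenyl.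

Among the measured compounds shown here, only one measured step bears on this change. The step of a number 23 percentage points higher from compound 1 to compound 2 (beyond the scatter) also swaps hydrogen and a group on an aromatic carbon, but the group is methoxy and it sits elsewhere, so it is a loose guide. The hydrogen compound is the higher one in that pair, so a small downward step is expected here, of lesser size and perhaps none beyond the scatter. The expected change is a number 8 percentage points lower from compound 2 to compound 3 (within the scatter) in this estimate. For compound 3 the estimated value is 58% with an expected range from 38% to 76% overall.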

Compound 3, percent of the compound remaining: 57%
The estimate for compound 3 lay 1 percentage points above the measured number; the measured number falls inside the stated range.
By their numbers in this assay, from the lowest: compound 1; then compounds 3 and 2 (each within the scatter of the next).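

In this assay, among the compounds shown here, the replacement of hydrogen by methyl ortho to a carboxy group, which turns 4-carboxyphenyl into 4-carboxy-3-methylphenyl, gives a number 9 percentage points lower from compound 2 to compound 3 (within the scatter) and so leaves no step that can be told from the scatter. For the compounds shown here, the only earlier step, a number 23 percentage points higher from compound 1 to compound 2 (beyond the scatter) for hydrogen in place of methoxy, concerned a different group at a different place, so this result adds that not every group on this ring comes with a step beyond the scatter. It rests on a single pair and says nothing about this position beyond methyl. No measurement shown here offers an explanation for the result.

As far as these compounds go, what a group other than methyl would do at this position stays open, whether methoxy itself, which would separate the effect of the group from that of its place, or a chlorine atom or ethyl. Also open, from the compounds shown here alone, is whether the result would hold with an amide or a tetrazole in place of the carboxylic acid, or with a shorter or longer chain in place of the butylene link.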